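This account rests on a few compounds, and the source may have more. Where it says the series, first, only, none or still open, it means among the compounds named here.

Measured in an ADME assay (liver) for metabolic stability, with Liver microsome (Rattus norvegicus) as the target, using microsomes and NADPH, with a stated time of 30 min; a lower number here means slower removal, a higher number faster removal of the compound:
Compound 1 `CC#C[C@H]1CN(S(=O)(=O)c2ccc(N)nc2)CCN1c1ccccc1`: > 399 mL.min-1.g-1, which is a limit.
Compound 2 `C#CCC(O)(c1ccc(N2CCN(S(=O)(=O)c3ccc(N)nc3)C[C@@H]2C#CC)cc1)C(F)(F)F`: 59 mL.min-1.g-1.
Compound 3 `CC#C[C@H]1CN(S(=O)(=O)c2ccc(N)nc2)CCN1c1ccc(S(N)(=O)=O)cc1`: 30 mL.min-1.g-1.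

Compound 3 sits with compound 2, and the gap between them, a 2.0-fold lower number from compound 2 to compound 3 (0.29 log units; within the scatter), does not separate them. Compound 4 `CC#C[C@H]1CN(S(=O)(=O)c2ccc(N)nc2)CCN1c1ccc(S(=O)(=O)Nc2ccccc2)cc1` follows from compound 3 by phenyl in place of hydrogen on a sulfonamide nitrogen, with phenyl in place of hydrogen on a sulfonamide nitrogen. For the measured compounds named here, no measured step makes this change. The nearest guides are an at least 13-fold lower number from compound 1 to compound 3 (1.12 log units; beyond the scatter) and an at least 6.7-fold lower number from compound 1 to compound 2 (0.83 log units; beyond the scatter), both starting from the limit (the limit of > 399 mL.min-1.g-1 in this assay, at which 1 of the 3 values shown sits). Part of the drop in an at least 13-fold lower number from compound 1 to compound 3 (1.12 log units; beyond the scatter) may be given back, so a moderate rise is expected, a 2.3-fold higher number from compound 3 to compound 4 (0.37 log units; beyond the scatter). Compound 4 is estimated at 70 mL.min-1.g-1, with an expected range of 25 mL.min-1.g-1 to 200 mL.min-1.g-1.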

Compound 4, intrinsic clearance in microsomes: > 399 mL.min-1.g-1
Compound 4 gave a limit, no number; the forecaster's own chance of this, stated with the estimate: 8%; middle value at least 5.7-fold (0.75 log units) from the limit.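

In this assay, the sulfonamide nitrogen proves a sensitive place: phenyl in place of hydrogen gives an at least 13-fold higher number from compound 3 to compound 4 (1.12 log units; beyond the scatter), so the sulfamoyl group does not keep its low number once that hydrogen is replaced. The step to the other substituted compound is an at least 6.7-fold higher number from compound 2 to compound 4 (0.83 log units; beyond the scatter). Compound 4, like compound 1, stands at a limit, so the step between them cannot be read: the limit of > 399 mL.min-1.g-1 in this assay, at which 2 of the 4 values shown sit.

Open, as far as these compounds go, is how methyl or a longer alkyl chain on the sulfonamide nitrogen would read in this assay, and whether a phenyl bearing a carboxylic acid would read differently from phenyl itself.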